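This account rests on a few compounds, and the source may have more. Where it says the series, first, only, none or still open, it means among the compounds named here.

Of the compounds shown here, three sharing one core have been measured in a physicochemical assay for solubility, measured as kinetic solubility; on this read-out lower numbers stand for lower solubility and higher numbers for higher solubility. Compound 1 `Cc1cc(C)c(CN2CCc3c(Cl)cc([C@H](CO)[C@H]4CCCO4)c(Cl)c3C2=O)c(=O)[nH]1` gives 430000 nM, and compound 2 `Cc1cc(C)c(CN2CCc3c(Cl)cc(C(CO)c4ccon4)c(Cl)c3C2=O)c(=O)[nH]1` gives 596000 nM; 481000 nM (2 entries) across its two entries. Compound 3 `Cc1cc(C)c(CN2CCc3c(Cl)cc([C@H](CO)[C@@H]4CCCO4)c(Cl)c3C2=O)c(=O)[nH]1` gives 400000 nM, which stands within the scatter of compound 1. The spread in the several entries of compound 2 in this assay, 596000 nM; 481000 nM (2 entries) shows how far repeat entries of a single compound can lie apart.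

The next compound is compound 4 `Cc1cc(C)c(CN2CCc3c(Cl)cc([C@@H](CO)[C@H]4CCCO4)c(Cl)c3C2=O)c(=O)[nH]1`, and the change is the two compounds have the same atoms and bonds and differ only in configuration as drawn: 2 of 2 stereo elements differ (all stereocentres are inverted: mirror images); a stereocentre at a saturated chain carbon is drawn R in compound 3 and S in compound 4; a stereocentre at a saturated ring carbon is drawn S in compound 3 and R in compound 4. Compound 4 is thus the mirror image of compound 3: the saturated chain carbon goes from R to S and the saturated ring carbon from S to R, while nothing leaves or enters.

Within the data shown here, one measured step bears on this, a 1.1-fold lower number from compound 1 to compound 3 (0.03 log units; within the scatter), and it is relevant because of the fact that compounds 1 and 3 differ only in the configuration as drawn. That step inverts only the ring stereocentre. Among the measured compounds shown here, no measured step inverts the chain stereocentre, alone or together with the ring stereocentre. For the measured compounds named here, with the only configurational step lying within the scatter, no change beyond the scatter is expected in this assay, and no direction can be favoured. The expected step is a 1.0-fold higher number from compound 3 to compound 4 (0.01 log units; within the scatter). For compound 4 the estimated value is 410000 nM, with an expected range from 260000 nM to 640000 nM.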

Compound 4, solubility: 576000 nM
Compound 4: the middle estimate sits 1.4-fold (0.15 log units) below what was measured; low and high end bracket the measured number.
By their numbers in this assay, from the lowest: compounds 3, 1 and 4 (each within the scatter of the next).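

Among these compounds, the saturated chain carbon is inverted here for the first time: on its own this gives a 1.3-fold higher number from compound 1 to compound 4 (0.13 log units; within the scatter), and together with the ring stereocentre it gives a 1.4-fold higher number from compound 3 to compound 4 (0.16 log units; within the scatter). With the earlier 1.1-fold lower number from compound 1 to compound 3 (0.03 log units; within the scatter), every configurational step among compound 1, compound 3 and compound 4 in this assay now lies within the scatter, and none of the three compounds goes against this, not even the mirror-image pair. How little weight these small steps can carry is seen from how far repeat entries of one compound lie apart, as in: the several entries of compound 2 in this assay, 596000 nM; 481000 nM (2 entries)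

The compounds shown leave open the remaining combination of the two stereocentres, with the saturated chain carbon and the saturated ring carbon both drawn S, so the configurational picture covers only part of the set. They also leave open whether the read-out would stay as insensitive once the substituent on the saturated chain carbon carries an amine or a carboxylic acid, since every comparison of configuration here rests on a single set of atoms and bonds.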